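A thiourea replaces a carbamate on a shared core

This account rests on a few compounds, and the source may have more. Where it says the series, first, only, none or still open, it means among the compounds named here.

Compound 1 `CC1(C)CC(NC(=O)NCc2ccccc2)c2cc(Cl)ccc2O1`: 15000 nM
Compound 2 `CCOC(=O)NC1CC(C)(C)Oc2ccc(Cl)cc21`: "not determined" (no result reported)
Compound 3 `CC1(C)CC(NC(=O)Nc2cccc(Cl)c2)c2cc(Cl)ccc2O1`: 25000 nM

In a functional assay on T98G cells (Homo sapiens) for inhibition, read by MTT assay, with a stated time of 72 h (a lower number here means a stronger inhibitor, a higher number a weaker inhibitor), compound 1 gives 15000 nM and compound 3 gives 25000 nM. The one step among these, a 1.7-fold higher number from compound 1 to compound 3 (0.22 log units; within the scatter), shows that exchanging one group for another on the urea nitrogen of this core leaves the number where it was. Compound 2 stands nowhere on the numbers: in this assay compound 2 gives "not determined" (no result reported), so it gives no anchor of its own.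

Compound 4 `CC(C)NC(=S)NC1CC(C)(C)Oc2ccc(Cl)cc21` differs from compound 2 by a group of 6 heavy atoms (4 carbon, 1 nitrogen, 1 sulfur; no ring) in place of a group of 5 heavy atoms (3 carbon, 2 oxygen; no ring), on an amine nitrogen. The step from compound 1 to compound 3 bears on this only loosely, since it concerns a different substituent, yet both measured compounds sit at weak inhibition in this assay, and the carbamate compound 2 offers no contrary number. A step beyond the scatter is therefore not expected in either direction; compound 4 is expected to come out in the same weak range, with wide uncertainty because it is read off compounds 1 and 3 alone.

Compound 4 is estimated at 20000 nM, between 5000 nM and 80000 nM.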

Compound 4, half-maximal inhibitory concentration: 91000 nM
Beside the measured number, compound 4's estimate is 4.6-fold (0.66 log units) below it; the measured number lies above the stated range.
By their numbers in this assay, from the lowest: compounds 1 and 3 (each within the scatter of the next); then compound 4.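

Compound 2 carries no number in this assay, so the step from compound 2 to compound 4 cannot be read. No measurement shown here accounts for the value of compound 4. The compounds shown leave open whether replacing ethoxycarbonyl on that amine nitrogen changes the number at all.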